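Diethylamino for dimethylamino on a longer chain

This account rests on a few compounds, and the source may have more. Where it says the series, first, only, none or still open, it means among the compounds named here.

Measured so far:
compound 1 `CN(C)CCCn1c(N)c(-c2nc3ccccc3[nH]2)c2nc(C#N)c(C#N)nc21` — 25900 nM
compound 2 `CCN(CC)CCCn1c(N)c(-c2nc3ccccc3[nH]2)c2nc(C#N)c(C#N)nc21` — 3150 nM
compound 3 `CN(C)CCCCn1c(N)c(-c2nc3cc(Cl)ccc3[nH]2)c2nc(C#N)c(C#N)nc21` — 3120 nM

In a functional assay on HeLa cells (Homo sapiens) for antiproliferative activity, read by MTT assay, with a stated time of 48 h (a higher number here means a weaker inhibitor, a lower number a stronger inhibitor), compound 1 gives 25900 nM. Compound 2 carries diethylamino in place of dimethylamino on a saturated chain carbon, three bonds along the chain from an aromatic nitrogen and gives 3150 nM, a step of an 8.2-fold lower number from compound 1 to compound 2 (0.91 log units; beyond the scatter). Compound 3, built on a different core, gives 3120 nM; the difference between the two cores is not broken down here. Compound 4 `CCN(CC)CCCCn1c(N)c(-c2nc3cc(Cl)ccc3[nH]2)c2nc(C#N)c(C#N)nc21` carries diethylamino in place of dimethylamino on a saturated chain carbon, four bonds along the chain from an aromatic nitrogen; this is the same kind of change as in compound 2, but its place lies four bonds rather than three bonds along the chain from the aromatic nitrogen. From compound 3 to compound 4 a step of a 5.2-fold lower number from compound 3 to compound 4 (0.72 log units; beyond the scatter) is expected in this assay, resting on the step of an 8.2-fold lower number from compound 1 to compound 2 (0.91 log units; beyond the scatter), with room left for the different chain length and core. Compound 4 is thus estimated at 600 nM, between 150 nM and 2500 nM.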

Compound 4, half-maximal inhibitory concentration: 3640 nM
Estimate against measurement, compound 4: 6.1-fold (0.78 log units) below; measured number above the stated range.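

In this assay, the same change on the core of compound 3 gives a 1.2-fold higher number from compound 3 to compound 4 (0.07 log units; within the scatter), so the step seen on the core of compound 1 does not reappear here. The two steps differ: the same change on two cores in this assay, an 8.2-fold lower number (0.91 log units; beyond the scatter) from compound 1 to compound 2 and a 1.2-fold higher number (0.07 log units; within the scatter) from compound 3 to compound 4, 9.6-fold (0.98 log units) apart, beyond the scatter of two such steps This shows that the size of the change cannot simply be carried from one core to another in this series; it does not show whether chain length or the rest of the core accounts for the difference, as the two pairs differ in both.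

As far as these compounds go, it remains open what the change does on the core of compound 1 at four bonds along the chain, or on the core of compound 3 at three. A piperidine or morpholine in place of diethylamino also remains untested among the compounds shown.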